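Aminophenyl Replaces Dimethoxyphenyl on the Sulfonyl Sulfur

The source may report more compounds than this note shows. Statements on the series, on what has been measured and on what is new or still open speak of the compounds shown alone.

Three compounds share one core and differ only in the aryl group on a sulfonyl sulfur. In an assay on brain for displacement of a labelled ligand from 5-hydroxytryptamine receptor 4 (Cavia porcellus), with a stated time of 30 min, in the presence of a further agent that is not named here (a lower number here means a stronger inhibitor, a higher number a weaker inhibitor), compound 1 `COc1cc(N)c(Cl)cc1C(=O)CCC1CCN(CCNS(=O)(=O)c2cc(Br)ccc2Br)CC1` gives 16.3 nM, compound 2 `COc1cc(N)c(Cl)cc1C(=O)CCC1CCN(CCNS(=O)(=O)c2ccc(C)cc2)CC1` gives 18 nM, and compound 3 `COc1ccc(S(=O)(=O)NCCN2CCC(CCC(=O)c3cc(Cl)c(N)cc3OC)CC2)cc1OC` gives 8.2 nM. Compound 3 shows the lowest of the three numbers: a 2.0-fold lower number from compound 1 to compound 3 (0.30 log units; within the scatter), while a 2.2-fold lower number from compound 2 to compound 3 (0.34 log units; beyond the scatter); for comparison, a 1.1-fold higher number from compound 1 to compound 2 (0.04 log units; within the scatter). Compound 4 `COc1cc(N)c(Cl)cc1C(=O)CCC1CCN(CCNS(=O)(=O)c2ccc(N)cc2)CC1` differs from compound 3 by 4-aminophenyl in place of 3,4-dimethoxyphenyl on a sulfonyl sulfur. All three measured steps exchange this same aryl group, and only one of them went beyond the scatter, so a further exchange is expected to move this assay little, if at all. The expected step is a 1.6-fold higher number from compound 3 to compound 4 (0.20 log units; within the scatter). Compound 4 is therefore estimated to give 13 nM in this assay, within a range of 5 nM to 35 nM.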

Compound 4, inhibition constant: 1.97 nM
Estimate against measurement, compound 4: 6.6-fold (0.82 log units) above; the measured number lies below the stated range.
By their numbers in this assay, from the lowest: compound 4; then compounds 3, 1 and 2 (each within the scatter of the next, the first and the last beyond it).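

Among the compounds shown here, the aryl group on the sulfonyl sulfur matters more in this assay than the earlier compounds suggested, since 4-aminophenyl in place of 3,4-dimethoxyphenyl gives a clear gain (a 4.2-fold lower number from compound 3 to compound 4 (0.62 log units; beyond the scatter)) and the gain over 2,5-dibromophenyl is greater still (an 8.3-fold lower number from compound 1 to compound 4 (0.92 log units; beyond the scatter)). For the compounds shown here, the closest comparison is amino in place of methyl on an aromatic carbon (a 9.1-fold lower number from compound 2 to compound 4 (0.96 log units; beyond the scatter)), where only that one group on the ring changes. No measurement shown here accounts for these steps.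

On these data alone, whether a hydroxyl, a dimethylamino or an acetamido group in place of the amino would keep this low number stays open. So does whether the amino group would act the same way elsewhere on the ring.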